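Carbonyl substituent series: from compound 3 to compound 4

This account rests on a few compounds, and the source may have more. Where it says the series, first, only, none or still open, it means among the compounds named here.

Measured in a functional assay on HT-1080 cells (Homo sapiens) for antiproliferative activity, read by sulforhodamine B assay, with a stated time of 48 h; on this read-out lower numbers stand for stronger inhibition and higher numbers for weaker inhibition:
compound 1 `CCC(=O)Nc1ccc(S(=O)(=O)Oc2ccccc2I)cc1` gives 7200 nM
compound 2 `CC(C)(C)C(=O)Nc1ccc(S(=O)(=O)Oc2ccccc2I)cc1` gives 2600 nM
compound 3 `O=C(CCCCl)Nc1ccc(S(=O)(=O)Oc2ccccc2I)cc1` gives 12000 nM

Compound 3 carries the highest number of the three; compound 1 sits within the scatter of it, whereas the step of a 4.6-fold higher number from compound 2 to compound 3 (0.66 log units; beyond the scatter) is beyond the scatter. Compound 4 `CCCCCNC(=O)Nc1ccc(S(=O)(=O)Oc2ccccc2I)cc1` differs from compound 3 by pentylamino in place of 3-chloropropyl on a carbonyl carbon. Going by the values given here, no measured step introduces a nitrogen on this carbonyl carbon. Among the compounds with values here, the steps that bear on the position are a 2.8-fold lower number from compound 1 to compound 2 (0.44 log units; beyond the scatter) and a 4.6-fold higher number from compound 2 to compound 3 (0.66 log units; beyond the scatter), both modest, while a 1.7-fold higher number from compound 1 to compound 3 (0.22 log units; within the scatter) stayed within the scatter. Chain variation here has therefore moved this assay only modestly, and for compound 4 no step beyond the scatter is expected, a 1.3-fold lower number from compound 3 to compound 4 (0.12 log units; within the scatter). Compound 4 is estimated at 9000 nM, with a range from 3000 nM to 25000 nM.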

Compound 4, half-maximal inhibitory concentration: 6900 nM
Estimate against measurement, compound 4: 1.3-fold (0.12 log units) above; low and high end bracket the measured number.
By their numbers in this assay, from the lowest: compound 2; then compounds 4, 1 and 3 (each within the scatter of the next).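

In this assay, going by these compounds alone, pentylamino is the first group on this carbonyl carbon that carries a nitrogen, and it leaves the number level with the open-chain groups: a 1.7-fold lower number from compound 3 to compound 4 (0.24 log units; within the scatter) and a 1.0-fold lower number from compound 1 to compound 4 (0.02 log units; within the scatter) both stay within the scatter. Tert-butyl remains the one group that stands apart, with a 2.7-fold higher number from compound 2 to compound 4 (0.42 log units; beyond the scatter) beyond the scatter. No evidence at hand bears on this result.

Open, as far as these compounds go, is whether tert-butylamino on this carbonyl carbon would follow tert-butyl or pentylamino. Also open, from the compounds shown here alone, is how a shorter chain on the nitrogen, such as ethylamino, would compare with pentylamino.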